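The compounds below may be only part of what the source reports. "The series", "measured", "known", "first", "only" and "open" are said of these compounds alone.

Measured so far in a functional assay on RAW264.7 cells (Mus musculus) for inhibition, read by Griess assay, with a stated time of 20 h; on this read-out higher numbers stand for weaker inhibition and lower numbers for stronger inhibition:
- compound 1 `CCCNC(=O)c1cc(-n2cc(-c3ccccc3)nn2)ccc1O`: > 20000 nM (a limit)
- compound 2 `CCCNC(=O)c1cc(-n2cc(-c3cc(F)cc(F)c3)nn2)ccc1O`: > 20000 nM (a limit)

Compound 1 has only a limit and no number, and it sits at the limit of > 20000 nM in this assay, at which 2 of the 2 values shown sit. Not yet measured is compound 3 `O=C(c1cc(-n2cc(-c3ccccc3)nn2)ccc1O)N1CCCCC1`, and the change from compound 1 is piperidin-1-yl in place of propylamino on a carbonyl carbon. Among the measured compounds shown here, the only measured step, a step that the two limits leave unreadable from compound 1 to compound 2, lies at a different place and gives no size to carry over. No shift beyond the scatter is therefore expected in this assay, in either direction, and a further limit is the likeliest report. The estimated step is a step that the limit leaves unreadable from compound 1 to compound 3. The expected value for compound 3 is 25000 nM, with an estimated range of 10000 nM to 60000 nM.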

Compound 3, half-maximal inhibitory concentration: > 20000 nM
Compound 3: a limit, no number (the forecaster's own chance of this, stated with the estimate: 75%); the middle value does not contradict the limit.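

In this assay, compound 1 and compound 3 each give only a limit, so no step can be read between them: the limit of > 20000 nM in this assay, at which 3 of the 3 values shown sit.

The compounds shown leave open whether any change to the core of compound 1 gives a measurable number in this assay.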